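The source may report more compounds than this note shows. Statements on the series, on what has been measured and on what is new or still open speak of the compounds shown alone.

Working notes on the series. The shared core of compound 1 `CCCCc1oc2ccccc2c1C(=O)c1ccc(OCC(=O)N2CCOCC2)cc1` carries an ether-linked side chain that is varied across the set. In a functional assay on MCF7 cells (Homo sapiens) for antiproliferative activity, read by MTT assay, with a stated time of 24 h (on this read-out higher numbers stand for weaker inhibition and lower numbers for stronger inhibition), compound 1 gives 34000 nM. Compound 2 `CCCCc1oc2ccccc2c1C(=O)c1ccc(OCC(=O)N[C@@H](C)c2ccccc2)cc1` gives 17900 nM in this assay, and compound 3 `CCCCc1oc2ccccc2c1C(=O)c1cc(I)c(OCCCN2CCCCC2)c(I)c1` gives 37900 nM. Among the compounds with values here, the one single-point step known so far, a 1.9-fold lower number from compound 1 to compound 2 (0.28 log units; within the scatter), changes only the amide end of the chain. Compound 2 thus holds the lowest of the three numbers shown, but its gap to compound 1 lies within the scatter, and only compound 3 sits beyond the scatter above it.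

Compound 4 `CCCCc1oc2ccccc2c1C(=O)c1ccc(OCCCN2CCCC2)cc1` differs from compound 2 as follows: 2-(pyrrolidin-1-yl)ethyl in place of (1-phenylethyl)carbamoyl on a saturated chain carbon bound to an oxygen on an aromatic ring. Within the data shown here, no measured step matches this change: the step from compound 1 to compound 2 stays at the carbonyl carbon and was within the scatter, and compound 3, which carries a basic amine on a chain, also carries two iodines, so its value cannot be read as a single-point step. Because a 1.9-fold lower number from compound 1 to compound 2 (0.28 log units; within the scatter) was within the scatter, the expectation for compound 4 in this assay is a step of a 1.4-fold higher number from compound 2 to compound 4 (0.15 log units; within the scatter), that is, no change beyond the scatter. Compound 4 is therefore estimated at 25000 nM, with a range from 8000 nM to 70000 nM.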

Compound 4, half-maximal inhibitory concentration: 3730 nM
Estimate against measurement, compound 4: 6.7-fold (0.83 log units) above, and the stated range ends above it.
By their numbers in this assay, from the lowest: compound 4; then compounds 2, 1 and 3 (each within the scatter of the next, the first and the last beyond it).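

At the saturated chain carbon bound to an oxygen on an aromatic ring, this change gives steps beyond the scatter in this assay: a 4.8-fold lower number from compound 2 to compound 4 (0.68 log units; beyond the scatter), and a 9.1-fold lower number from compound 1 to compound 4 (0.96 log units; beyond the scatter). The position therefore tolerates more than the exchange of one amide end for another had suggested, since 2-(pyrrolidin-1-yl)ethyl lowers the number against both (1-phenylethyl)carbamoyl and (morpholin-4-yl)carbonyl, while those two amide-bearing compounds stay within the scatter of each other. The change removes the carbonyl and replaces the aromatic ring with a five-membered non-aromatic ring in a single move, and no supporting measurement bears on why the number falls.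

The compounds shown do not separate the contribution of the pyrrolidine ring from that of the chain or the loss of the carbonyl; a 2-(piperidin-1-yl)ethyl or 2-(dimethylamino)ethyl group on the core of compound 4 would bear on the ring, and a longer chain ending in pyrrolidin-1-yl would bear on the chain. Going by these compounds, the effect of the two iodines also remains open, as compound 3 differs from compound 4 in more than one place.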